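This account rests on a few compounds, and the source may have more. Where it says the series, first, only, none or still open, it means among the compounds named here.

Measured so far in a functional assay on A549 cells (Homo sapiens) for inhibition, read by CCK-8 assay, with a stated time of 72 h, tested at 1 uM; a lower number here means less inhibition of growth, a higher number more inhibition of growth at the concentration tested:
- compound 1 `CN(C)C(=O)c1cc2cnc(Nc3ccc(NC(=O)C4(C(=O)Nc5ccc(C(F)(F)F)cc5)CC4)cc3)nc2n1C1CCCC1` gives -25.3%
- compound 2 `CN(C)C(=O)c1cc2cnc(Nc3ccc(NC(=O)C4(C(=O)Nc5ccccc5)CC4)cc3)nc2n1C1CCCC1` gives 75%

Compound 2 stands at 75% in this assay and holds the higher of the two numbers, well clear of compound 1. Compound 3 `CN(C)C(=O)c1cc2cnc(Nc3ccc(NC(=O)C4(C(=O)Nc5ccc(C#N)cc5)CC4)cc3)nc2n1C1CCCC1` has not yet been measured. It carries cyano in place of hydrogen on an aromatic carbon and so turns the phenylcarbamoyl of compound 2 into (4-cyanophenyl)carbamoyl.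

Among the compounds with values here, only one measured step bears on this change, a number 100.3 percentage points higher from compound 1 to compound 2 (beyond the scatter) as hydrogen replaces trifluoromethyl on that same carbon. That step is large and beyond the scatter. Read in reverse, it links a group at this place with a far lower number. Still, it rests on a single pair, and cyano is a different group from trifluoromethyl. A fall is therefore expected, probably a smaller one, and the estimated step is a number 50 percentage points lower from compound 2 to compound 3 (beyond the scatter) with considerable uncertainty. In this assay compound 3 is expected at about 25% with an estimated range from -20% to 70% for a single measurement.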

Compound 3, percent growth inhibition at one concentration: 86.1%
Compound 3: the middle estimate sits 61.1 percentage points below what was measured; measured number above the stated range.
By their numbers in this assay, from the lowest: compound 1; then compound 2; then compound 3.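

In this assay, a group on this aromatic carbon, para to a large group, is not penalised as such: cyano in place of hydrogen gives a number 11.1 percentage points higher from compound 2 to compound 3 (beyond the scatter), so the far lower number seen earlier goes with trifluoromethyl and not with every group at this place. Exchanging trifluoromethyl for cyano on the same carbon gives a number 111.4 percentage points higher from compound 1 to compound 3 (beyond the scatter), which shows that among these compounds the outcome turns on which group sits here rather than on whether one sits here at all. No measurement shown here speaks to what lies behind this difference between the two groups.

With only hydrogen, cyano and trifluoromethyl shown on this carbon, it remains open whether trifluoromethyl is an isolated exception or marks a wider set of groups that lower the number, and a fluorine or chlorine atom, a methoxy group or an amine here could fall on either side. On these data alone, it is also open whether the gain with cyano would persist with the group on another carbon of the same ring, or at other concentrations in this assay.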